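Removing the Methylcarbamoyl: Fluoro at the Biaryl Terminus

A few compounds are considered here, and "the series" means these few. Any claim that something is new, unique, unknown or untested is made for them only; others in the source may bear on it.

Compound 1 `COc1ccccc1C(=O)NCCNc1cccc(NS(=O)(=O)c2cc(-c3ccccc3)ccc2OC)c1` gives > 10000 nM in an assay on CHO-K1 cells for agonist activity at Orexin receptor type 2 (Homo sapiens), read by a luciferase reporter (a higher number here means that more compound is needed for the effect, a lower number that less compound is needed), a limit of the assay rather than a number.
Compound 2 `COc1cccc(-c2ccc(OC)c(S(=O)(=O)Nc3cccc(NCCNC(=O)c4ccccc4OC)c3)c2)c1` gives 800 nM in this assay.
Compound 3 `CNC(=O)c1cccc(-c2ccc(OC)c(S(=O)(=O)Nc3cccc(NCCNC(=O)c4ccccc4OC)c3)c2)c1` gives 182 nM in this assay.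

Compound 3 stands at the lowest of the two numbers, with compound 2 the nearest, a 4.4-fold lower number from compound 2 to compound 3 (0.64 log units; beyond the scatter). Compound 4 `COc1ccccc1C(=O)NCCNc1cccc(NS(=O)(=O)c2cc(-c3cccc(F)c3)ccc2OC)c1` differs from compound 3 by fluoro in place of methylcarbamoyl on an aromatic carbon. Among the compounds with values here, the steps that bear on this change are those that build up the substituent at this position: an at least 12-fold lower number from compound 1 to compound 2 (1.09 log units; beyond the scatter) and an at least 54-fold lower number from compound 1 to compound 3 (1.73 log units; beyond the scatter), both large. Compound 4 carries neither the methoxy of compound 2 nor the methylcarbamoyl of compound 3, but only a fluoro; its closest measured relative in this respect is compound 1, which sits at the limit (the limit of > 10000 nM in this assay, at which 1 of the 3 values shown sits). A large step upward is therefore expected, a 27-fold higher number from compound 3 to compound 4 (1.44 log units; beyond the scatter), undoing most of what the methylcarbamoyl brought. Compound 4 is estimated at 5000 nM, within a range from 1500 nM to 20000 nM, with a real chance that only a limit is reported.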

Compound 4, half-maximal effective concentration: > 10000 nM
Compound 4: only a limit was reported (the forecaster's own chance of this, stated with the estimate: 40%); middle value at least 2.0-fold (0.30 log units) away from the limit.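

The 3-fluorophenyl of compound 4 does not keep the gain seen with the other two groups on this aromatic carbon, with an at least 54-fold higher number from compound 3 to compound 4 (1.73 log units; beyond the scatter) and an at least 12-fold higher number from compound 2 to compound 4 (1.09 log units; beyond the scatter). In this assay compound 4 stands at a limit of the assay, not at a number: the limit of > 10000 nM in this assay, at which 2 of the 4 values shown sit.

So among the compounds shown, a substituent at this place is not enough in itself: methoxy and methylcarbamoyl each give a measured number, while fluoro gives none.

Going by these compounds, whether fluoro changes anything relative to hydrogen stays open, since compound 1 and compound 4 both stand at limits and the step between them cannot be read. Also open, on these data alone, is which part of the methylcarbamoyl matters, and how a primary carboxamide, a carboxylic acid or an aminomethyl group would stand on the same carbon.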